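Swapping an aryl amide for an acetyl group on a shared core

The source may report more compounds than this note shows. Statements on the series, on what has been measured and on what is new or still open speak of the compounds shown alone.

Compound 1 (`O=C(Nc1ccc2nc(Nc3ccc(Cl)c(Cl)c3)c(Nc3ccc(Cl)c(Cl)c3)nc2c1)c1cccc(C(F)(F)F)c1`) carries two dichlorophenyl amino groups on its core and a (3-(trifluoromethyl)phenyl)carbonyl amide on the ring. In a toxicity assay on HepG2 cells (Homo sapiens) for cytotoxicity, read by MTT assay, with a stated time of 24 h (on this read-out higher numbers stand for lower toxicity in this test and lower numbers for higher toxicity in this test), compound 1 gives "nd" (no result reported), that is, no result was reported, so it stands without a number. Two relatives of compound 1 were measured. Compound 2 (`O=[N+]([O-])c1ccc2nc(Nc3ccccc3)c(Nc3ccccc3)nc2c1`), with a nitro group in place of the amide and plain phenyl amino groups, gives 12600 nM. Compound 3 (`O=[N+]([O-])c1ccc2nc(Nc3ccc(F)c(C(F)(F)F)c3)c(Nc3ccc(F)c(C(F)(F)F)c3)nc2c1`), again with a nitro group but with fluoro and trifluoromethyl groups on the phenyl rings, gives 7750 nM. These two values sit within the scatter of each other, so neither can be called more or less toxic than the other.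

Compound 4 (`CC(=O)Nc1ccc2nc(Nc3ccc(Cl)c(Cl)c3)c(Nc3ccc(Cl)c(Cl)c3)nc2c1`) is compound 1 with one change: methyl in place of 3-(trifluoromethyl)phenyl on a carbonyl carbon. Since no measurement of compound 1 exists, the step cannot be computed. The expectation is that this change brings no shift beyond the scatter in this assay, placing compound 4 near the two measured relatives.

Compound 4 is expected to give about 10000 nM in this assay, with a plausible range from 3000 nM to 35000 nM.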

Compound 4, half-maximal cytotoxic concentration: 8600 nM
Beside the measured number, compound 4's estimate is 1.2-fold (0.07 log units) above it; low and high end bracket the measured number.
By their numbers in this assay, from the lowest: compounds 3, 4 and 2 (each within the scatter of the next).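

Among the compounds shown here, compound 1, the only compound here that differs from compound 4 in one place, has no number in this assay so no step can be read between them. Going by these compounds, what replacing 3-(trifluoromethyl)phenyl with methyl does to toxicity in this test remains open, as does the separate effect of each group on the shared core. No other measurement here bears on the value of compound 4.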